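Chain extension at the isothiocyanate linker of compound 2

The source may report more compounds than this note shows. Statements on the series, on what has been measured and on what is new or still open speak of the compounds shown alone.

Measured so far:
compound 1, `CN(C)C(=O)c1cc2cnc(Nc3ccc(S(=O)(=O)NCCCN=C=S)cc3)nc2n1C1CCCC1`: 102%
compound 2, `CN(C)C(=O)c1cc2cnc(Nc3ccc(NC(=O)CCCCCN=C=S)cc3)nc2n1C1CCCC1`: 100%

In a functional assay on A549 cells (Homo sapiens) for inhibition, read by CCK-8 assay, with a stated time of 72 h, tested at 10 uM (on this read-out lower numbers stand for a weaker effect and higher numbers for a stronger effect at the one concentration tested), compound 1 gives 102% and compound 2 gives 100%. Compound 2 holds the lowest of the two numbers, and its nearest neighbour is compound 1; the step of a number 2 percentage points lower from compound 1 to compound 2 (within the scatter) lies within the scatter, so the two compounds are not separable on this read-out. Compound 3, `CN(C)C(=O)c1cc2cnc(Nc3ccc(NC(=O)CCCCCCN=C=S)cc3)nc2n1C1CCCC1`, has not yet been measured in this assay. It differs from compound 2 by a group of 4 heavy atoms (2 carbon, 1 nitrogen, 1 sulfur; no ring) in place of a group of 3 heavy atoms (1 carbon, 1 nitrogen, 1 sulfur; no ring), on a saturated chain carbon, five bonds along the chain from a carbonyl carbon. Among the measured compounds shown here, no measured step alters the length of this chain; the only step at hand, a number 2 percentage points lower from compound 1 to compound 2 (within the scatter), exchanges the whole linker and stays within the scatter. For compound 3 a step no larger than the scatter is therefore expected: a number 1 percentage points lower from compound 2 to compound 3 (within the scatter). Compound 3 is estimated at 99%, with a range from 90% to 106%.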

Compound 3, a percentage reported as inhibition, at one concentration (the size of the read-out at that concentration, not a potency): 102%
The estimate for compound 3 lay 3 percentage points below the measured number; measured number inside the range.
By their numbers in this assay, from the lowest: compounds 2, 1 and 3 (each within the scatter of the next).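

In this assay, among the compounds shown here, this is the first measured change in chain length at this position, on a saturated chain carbon, five bonds along the chain from a carbonyl carbon: the group of 4 heavy atoms in place of the group of 3 gives a number 2 percentage points higher from compound 2 to compound 3 (within the scatter). Exchanging the whole linker on the aromatic carbon gives no change at the digits printed from compound 1 to compound 3 (within the scatter), so neither this added chain carbon nor this linker exchange separates the compounds on this read-out. Nothing available bears on a cause for these results.

Still open, going by these compounds, is whether a much shorter or longer chain, or an amine or a carboxylic acid in place of the isothiocyanate, would keep the read-out within the scatter. A read-out at a single concentration also leaves open whether compound 1, compound 2 and compound 3 would differ in effect at any other concentration.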